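A few compounds are considered here, and "the series" means these few. Any claim that something is new, unique, unknown or untested is made for them only; others in the source may bear on it.

Among the three compounds measured so far, compound 3 `CCCCCCCCCCCNC(=O)[C@H]1OC(n2cnc3c(N)ncnc32)[C@H](O)[C@@H]1O` gives the highest number in an assay on cell membranes for binding affinity to 2-oxoglutarate receptor 1 (Rattus norvegicus), read by radioligand binding (a lower number here means a stronger inhibitor, a higher number a weaker inhibitor), at 123 nM. Compound 1 `CCCCNC(=O)[C@H]1OC(n2cnc3c(N)ncnc32)[C@H](O)[C@@H]1O` gives 17 nM in this assay, and compound 2 `CCCCCCCCCNC(=O)[C@H]1OC(n2cnc3c(N)ncnc32)[C@H](O)[C@@H]1O` gives 31 nM. The three share one core and differ only in the length of the chain on the amide nitrogen, and the numbers rise with that length: a 1.8-fold higher number from compound 1 to compound 2 (0.26 log units; within the scatter), a 7.2-fold higher number from compound 1 to compound 3 (0.86 log units; beyond the scatter), and a 4.0-fold higher number from compound 2 to compound 3 (0.60 log units; beyond the scatter).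

Compound 4 `CC(=O)NCCNC(=O)[C@H]1OC(n2cnc3c(N)ncnc32)[C@H](O)[C@@H]1O` is the next step from compound 3, with acetamido in place of nonyl on a saturated chain carbon, two bonds along the chain from an amide-type nitrogen. Among the measured compounds shown here, this both shortens the chain well below that of compound 1 and brings in a group with a hydrogen-bond donor and acceptor, for which no measured step exists. The measured steps bear on the chain length alone: they show that the longer chains of compound 2 and compound 3 gave higher numbers than compound 1, so cutting the chain back is expected to move the number down again, by roughly the size of a 7.2-fold higher number from compound 1 to compound 3 (0.86 log units; beyond the scatter) in reverse. As far as these compounds go, what the acetamido group itself adds is unknown, which widens the range. Compound 4 is therefore estimated to give 40 nM in this assay, between 8 nM and 200 nM, an expected step of a 3.1-fold lower number from compound 3 to compound 4 (0.49 log units; beyond the scatter).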

Compound 4, inhibition constant: 46 nM
The estimate for compound 4 lay 1.2-fold (0.06 log units) below the measured number; measured number inside the range.
By their numbers in this assay, from the lowest: compounds 1, 2 and 4 (each within the scatter of the next, the first and the last beyond it); then compound 3.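

The acetamido group shows that this position, so far occupied only by plain carbon chains, can also carry a chain ending in a carbonyl and an amide hydrogen without losing binding in this assay: acetamido in place of nonyl gives a clear improvement (a 2.7-fold lower number from compound 3 to compound 4 (0.43 log units; beyond the scatter)), and compound 2 and compound 4 cannot be told apart (a 1.5-fold higher number from compound 2 to compound 4 (0.17 log units; within the scatter)). Even so, the change does not match the best of the plain chains, as acetamido in place of ethyl still costs some binding (a 2.7-fold higher number from compound 1 to compound 4 (0.43 log units; beyond the scatter)), so compound 1 keeps its edge over compound 4. Nothing available explains why acetamido sits where it does in this series.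

Still open, as far as these compounds go, is whether the carbonyl, the amide hydrogen or simply the shorter chain accounts for the number of compound 4, and a longer chain ending in acetamido would help separate chain length from the end group. From the compounds shown here alone, how an amine or a carboxylic acid would read at this same place on the chain also remains unknown.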